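Working notes: a 4-methylpiperidin-1-yl analogue of compound 2

This account rests on a few compounds, and the source may have more. Where it says the series, first, only, none or still open, it means among the compounds named here.

Measured so far in a functional assay on HT-29 cells (Homo sapiens) for cytotoxicity, read by MTT assay, with a stated time of 72 h; a higher number here means a weaker inhibitor, a lower number a stronger inhibitor:
compound 1 `COc1cc2c(Oc3ccc(NC(=O)c4cn(-c5ccccc5C)nn4)cc3F)ccnc2cc1OCCCN1CCCCC1` gives 1340 nM
compound 2 `COc1cc2c(Oc3ccc(NC(=O)c4cn(-c5ccccc5F)nn4)cc3F)ccnc2cc1OCCCN1CCCCC1` gives 290 nM

For the measured compounds named here, compound 2 holds the lowest of the two numbers in this assay; the only measured step is a 4.6-fold lower number from compound 1 to compound 2 (0.66 log units; beyond the scatter), a change on an aromatic carbon. Compound 3 `COc1cc2c(Oc3ccc(NC(=O)c4cn(-c5ccccc5F)nn4)cc3F)ccnc2cc1OCCCN1CCC(C)CC1` differs from compound 2 by methyl in place of hydrogen on a saturated ring carbon. Going by the values given here, no measured step touches the saturated ring, so that single step gives no guidance here. In this assay no step beyond the scatter is therefore expected from compound 2 to compound 3, no change at the digits printed from compound 2 to compound 3 (within the scatter). Compound 3 is estimated at 290 nM, with a range from 120 nM to 700 nM.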

Compound 3, half-maximal inhibitory concentration: 210 nM
Estimate against measurement, compound 3: 1.4-fold (0.14 log units) above; the measured number falls inside the stated range.
By their numbers in this assay, from the lowest: compounds 3 and 2 (each within the scatter of the next); then compound 1.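

For the compounds shown here, the saturated ring is reached here for the first time: in this assay, methyl on the ring carbon three ring bonds from the ring nitrogen gives a 1.4-fold lower number from compound 2 to compound 3 (0.14 log units; within the scatter). This position therefore accepts a single methyl with no step beyond the scatter, whereas the earlier step concerned only an aromatic carbon. No evidence on hand bears on this result.

Going by these compounds, whether this ring carbon accepts a hydroxyl, a carboxylic acid or a longer chain in the same way stays open. A single methyl says nothing about those groups.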